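A few compounds are considered here, and "the series" means these few. Any claim that something is new, unique, unknown or untested is made for them only; others in the source may bear on it.

Measured compounds:
Compound 1, `COc1nc2ccc(Br)cc2cc1C(c1ccccc1)n1cc(-c2ccccc2F)nn1`: 14.1% in an ADME assay on HeLa cells (Homo sapiens) for cytotoxicity, read by sulforhodamine B assay, with a stated time of 48 h, tested at 10 uM; on this read-out lower numbers stand for less inhibition and higher numbers for more inhibition at the one concentration tested (going by the name of the read-out)
Compound 2, `COc1nc2ccc(Br)cc2cc1C(c1ccccc1)n1cc(CCCO)nn1`: 11.3% in this assay

Within the data shown here, only two compounds have been measured, and compound 2 provides the lower of the two numbers; the step of a number 2.8 percentage points lower from compound 1 to compound 2 (within the scatter) is small, so the two compounds cannot be told apart on this read-out. Compound 3, `COc1nc2ccc(Br)cc2cc1C(c1ccccc1)n1cc(-c2ccc(F)cc2)nn1`, has not yet been measured. It differs from compound 2 at one place: 4-fluorophenyl in place of 3-hydroxypropyl on an aromatic carbon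

Among the measured compounds shown here, the only measured step that bears on this change is a number 2.8 percentage points lower from compound 1 to compound 2 (within the scatter), which exchanged one aryl group for the 3-hydroxypropyl chain and moved the number by less than the scatter. Compound 3 restores an aryl group at the same place, a fluorophenyl as in compound 1, so compound 3 is expected to return toward the number of compound 1, which gives 14.1%. The expected step from compound 2 to compound 3 is therefore a number 2.7 percentage points higher from compound 2 to compound 3 (within the scatter), not beyond the scatter. Compound 3 is estimated at 14%, with a range from 4% to 25%.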

Compound 3, a percentage reported as inhibition, at one concentration (the size of the read-out at that concentration, not a potency): 4.27%
Compound 3: middle estimate off by 9.7 percentage points, on the high side; low and high end bracket the measured number.
By their numbers in this assay, from the lowest: compounds 3, 2 and 1 (each within the scatter of the next).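

In this assay, 4-fluorophenyl in place of 3-hydroxypropyl on the aromatic carbon of the five-membered aromatic ring with 3 nitrogen gives a number 7 percentage points lower from compound 2 to compound 3 (within the scatter), so this second pairing of an aryl group with the chain again fails to separate the two kinds of group on this read-out. The new compound also offers the first test of where the fluorine sits on the phenyl ring: 4-fluorophenyl in place of 2-fluorophenyl gives a number 9.8 percentage points lower from compound 1 to compound 3 (within the scatter), and so the two fluorophenyl groups cannot be told apart either. All three groups at this position therefore give numbers within the scatter of one another, and no information is available on what lies behind these numbers.

The compounds shown leave open whether any other kind of group at this position, such as an amine, a carboxylic acid or a longer chain, would give a number beyond the scatter. They also leave open whether a change elsewhere on the shared core would do so, as every compound here differs only at this one place.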